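The source may report more compounds than this note shows. Statements on the series, on what has been measured and on what is new or still open speak of the compounds shown alone.

Working notes on the series. In a functional assay on MCF7 cells (Homo sapiens) for inhibition, with a stated time of 72 h (on this read-out lower numbers stand for stronger inhibition and higher numbers for weaker inhibition), compound 1 `NC1CCC(Nc2nc(NCc3ccc(-c4cccc(F)c4)nc3)c3ncn(C4CCCC4)c3n2)CC1` gives 33 nM, and compound 2 `NC1CCC(Nc2nc(NCc3ccc(-c4ccco4)nc3)c3ncn(C4CCCC4)c3n2)CC1` gives 33 nM, which leaves compound 2 level with compound 1. For the measured compounds named here, the only measured step is no change at the digits printed from compound 1 to compound 2 (within the scatter). It concerns the group on an aromatic carbon, where furan-2-yl stands in place of 3-fluorophenyl.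

Compound 3 `OC1CCC(Nc2nc(NCc3ccc(-c4ccco4)nc3)c3ncn(C4CCCC4)c3n2)CC1` keeps the furan-2-yl group and carries 4-hydroxycyclohexyl in place of 4-aminocyclohexyl: hydroxy in place of amino on a saturated ring carbon. This is hydroxy in place of amino on a saturated ring carbon. Going by the values given here, no measured compound pair varies this place, so the flat step between the first two compounds does not set a size for the new change. Among the compounds with values here, the data hold no direct precedent for it, and any expectation here is a judgement on the structural change alone, with a wide margin. A moderate loss of inhibition in this assay is expected, though a result level with compound 2 is not excluded. The expected step is a 3.6-fold higher number from compound 2 to compound 3 (0.56 log units; beyond the scatter). For compound 3 the estimated value is 120 nM, with an expected range of 35 nM to 450 nM.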

Compound 3, half-maximal inhibitory concentration: 390 nM
Beside the measured number, compound 3's estimate is 3.3-fold (0.51 log units) below it, within the range that was stated.
By their numbers in this assay, from the lowest: compounds 1 and 2 (each within the scatter of the next); then compound 3.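

In this assay, for the compounds shown here, the earlier pair showed only that the group on the aromatic carbon could change without effect, with no change at the digits printed from compound 1 to compound 2 (within the scatter). Going by these compounds alone, the group on the saturated ring carbon behaves differently: hydroxy in place of amino gives a 12-fold higher number from compound 2 to compound 3 (1.07 log units; beyond the scatter), the first step beyond the scatter, so the read-out is sensitive to the group at this position. Amino and hydroxy have the same counts of heavy atoms, hydrogen-bond donors and hydrogen-bond acceptors, and neither carries a net charge, so these counts do not separate the two groups, and no measurement on hand accounts for the loss of inhibition.

Going by these compounds, the step is read only with furan-2-yl on the aromatic carbon, so its size with 3-fluorophenyl there remains open. Also open, on these data alone, is where a methylamino, a dimethylamino or an aminomethyl group, or a carboxylic acid, on the same saturated ring carbon would fall relative to compound 2 and compound 3, which would show whether the amino nitrogen itself matters or a wider range of groups is tolerated.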